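Amine substituent on the shared core: toward compound 4

The compounds below may be only part of what the source reports. "The series", "measured", "known", "first", "only" and "open" are said of these compounds alone.

Measured so far in a functional assay on HEK293 cells for agonist activity at Toll-like receptor 8 (Homo sapiens), read by reporter gene assay; a lower number here means that less compound is needed, a higher number that more compound is needed for the effect:
compound 1 `CCCCCNc1oc2c(C)ncc(CO)c2c1Nc1ccccn1` gives 5810 nM
compound 2 `CCOC(=O)CNc1oc2c(C)ncc(CO)c2c1Nc1ccccn1` gives "not active" (no number reported)
compound 3 `CCCC(C)Nc1oc2c(C)ncc(CO)c2c1Nc1ccccn1` gives 9010 nM

Going by the values given here, compound 3 carries the higher of the two numbers reported in this assay, but the only step that reaches it, a 1.6-fold higher number from compound 1 to compound 3 (0.19 log units; within the scatter), lies within the scatter, so compound 1 and compound 3 cannot be set apart. Compound 2, with an ethoxycarbonylmethyl group on the same nitrogen, gave no number at all.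

Compound 4 `Cc1ncc(CO)c2c(Nc3ccccn3)c(N)oc12` removes the side chain entirely: hydrogen in place of 1-methylbutyl on a nitrogen on an aromatic ring. Among the compounds with values here, no measured pair bears directly on this change; the single measured step, from compound 1 to compound 3, swaps one five-carbon chain for another and is flat. Within the data shown here, the result for compound 2 shows only that a different group on this nitrogen can abolish activity, not what a bare amino group does. Taking the chain as contributing to the weak activity seen, the expected step is a 2.8-fold higher number from compound 3 to compound 4 (0.44 log units; beyond the scatter), toward a weaker response, with a real chance that no number is obtained. The estimate for compound 4 in this assay is 25000 nM, within 7000 nM to 90000 nM.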

Compound 4, half-maximal effective concentration: "not active" (no number reported)
Nothing numeric was reported for compound 4, and the estimate cannot be compared.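

In this assay, going by these compounds alone, compound 4 gave "not active" with no number, and no step from compound 3 can be read. No separate evidence bears on this result. The compounds shown leave open whether any group on this nitrogen other than the pentyl and 1-methylbutyl of compound 1 and compound 3 gives a measurable number.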